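Trifluoromethoxy in place of trifluoromethyl on compound 1

This account rests on a few compounds, and the source may have more. Where it says the series, first, only, none or still open, it means among the compounds named here.

Compound 1 (`O=S1(=O)C=Cc2ccc(Nc3cccc(C(F)(F)F)c3)cc21`) gives 2500 nM in a functional assay on MCF7 cells (Homo sapiens) for antiproliferative activity, read by MTT assay, with a stated time of 72 h (on this read-out lower numbers stand for stronger inhibition and higher numbers for weaker inhibition), a number within the scatter of both compound 2 (`O=S1(=O)C=Cc2ccc(Nc3ccc(C(F)(F)F)cc3)cc21`) with 1270 nM and compound 3 (`O=S1(=O)C=Cc2ccc(Nc3ccc(Cl)cc3)cc21`) with 2670 nM in the same series. Compound 4 (`O=S1(=O)C=Cc2ccc(Nc3cccc(OC(F)(F)F)c3)cc21`) carries trifluoromethoxy in place of trifluoromethyl on an aromatic carbon and has no measured value yet. Going by the values given here, the only measured step that replaces trifluoromethyl is a 2.1-fold higher number from compound 2 to compound 3 (0.32 log units; beyond the scatter) for chloro, a modest one, so no step beyond the scatter is expected here in this assay for this different replacement. The expected change is a 1.1-fold lower number from compound 1 to compound 4 (0.06 log units; within the scatter) by this estimate. Compound 4 is estimated at 2200 nM with an expected range from 1000 nM to 4800 nM in this read-out.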

Compound 4, half-maximal inhibitory concentration: 2020 nM
For compound 4 the middle estimate is 1.1-fold (0.04 log units) above the measured one; measured number inside the range.
By their numbers in this assay, from the lowest: compounds 2, 4, 1 and 3 (each within the scatter of the next, the first and the last beyond it).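

Trifluoromethoxy in place of trifluoromethyl gives a 1.2-fold lower number from compound 1 to compound 4 (0.09 log units; within the scatter) in this assay and thus, at this place on an aromatic carbon, adds a hydrogen-bond acceptor without a step beyond the scatter. The only earlier replacement of trifluoromethyl, chloro on compound 2, had given a step beyond the scatter. Nothing shown bears on why the new step stays so small. The compounds shown leave open whether an amine or a carboxylic acid here would give a larger step, and whether trifluoromethoxy in place of trifluoromethyl on compound 2 would give a similar one.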